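The compounds below may be only part of what the source reports. "The series", "measured", "known", "first", "only" and "open" are said of these compounds alone.

Of the compounds shown here, three have so far been measured in a functional assay on HEK293 cells for agonist activity at D(4) dopamine receptor (Homo sapiens), read by FLIPR; a lower number here means that less compound is needed, a higher number that more compound is needed for the effect. Compound 1, `Cc1cc(C(=O)NCN2CCC(c3cccc[n+]3[O-])CC2)ccc1F`, gives 50 nM in this assay. Compound 2, `Cc1cc(C)cc(NC(=O)CN2CCC(c3cccc[n+]3[O-])CC2)c1`, gives 52 nM, a number within the usual scatter of that for compound 1. Compound 3, `c1ccc(C2CCN(Cc3nc4ccccc4[nH]3)CC2)nc1`, gives 12 nM, a lower number than compound 1 by more than the scatter, so compound 1 stands second highest of the three. Compound 4, `O=C(NCN1CCC(c2cccc[n+]2[O-])CC1)c1ccc(F)c(Cl)c1`, differs from compound 1 in one place: chloro in place of methyl on an aromatic carbon. For the measured compounds named here, no measured pair shows this change, so a small step is expected, in no particular direction, likely within the scatter. For compound 4 the estimate is 50 nM, between 20 nM and 130 nM. That amounts to an expected step of no change at the digits printed from compound 1 to compound 4 (within the scatter).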

Compound 4, half-maximal effective concentration: 63 nM
The estimate for compound 4 lay 1.3-fold (0.10 log units) below the measured number; the measured number falls inside the stated range.
By their numbers in this assay, from the lowest: compound 3; then compounds 1, 2 and 4 (each within the scatter of the next).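

For the compounds shown here, putting chloro in place of methyl gives a 1.3-fold higher number from compound 1 to compound 4 (0.10 log units; within the scatter), the first measured reading of this change at this position. In this one pair, 4-fluoro-3-methylphenyl and 3-chloro-4-fluorophenyl therefore cannot be told apart, while the rest of the compound stays the same. No measured information here explains this result.

As far as these compounds go, whether a methoxy group, a nitrile or a carboxylic acid at this position would move the number remains open. So does whether chloro in place of methyl would give a similar result on a different core.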